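The source may report more compounds than this note shows. Statements on the series, on what has been measured and on what is new or still open speak of the compounds shown alone.

Compound 1 `CCCCC(O)CC(=O)O[C@H](CC=C(C)C)C1=CC(=O)c2c(O)ccc(O)c2C1=O`, compound 2 `CC(=O)OCCC(=O)O[C@H](CC=C(C)C)C1=CC(=O)c2c(O)ccc(O)c2C1=O` and compound 3 `CCC(C)(O)CC(=O)O[C@H](CC=C(C)C)C1=CC(=O)c2c(O)ccc(O)c2C1=O` share one core and differ only in the ester chain. In a functional assay on HeLa cells (Homo sapiens) for cytotoxicity, read by MTT assay (on this read-out higher numbers stand for weaker inhibition and lower numbers for stronger inhibition), compound 1 gives 72200 nM, compound 2 gives 17300 nM and compound 3 gives 25200 nM. Compound 3 thus holds the second highest of the three numbers: there is a 1.5-fold higher number from compound 2 to compound 3 (0.16 log units; within the scatter), and a 2.9-fold lower number from compound 1 to compound 3 (0.46 log units; beyond the scatter). Compound 4 `CC[C@@](C)(O)CC(=O)O[C@H](CC=C(C)C)C1=CC(=O)c2c(O)ccc(O)c2C1=O` is the unmeasured one. (the two compounds have the same atoms and bonds; at least one stereo element is drawn with a configuration in one of them and without one in the other: 1 of 2 stereo elements differ; a stereocentre at a saturated chain carbon is drawn without a configuration in compound 3 and R in compound 4). Among the compounds with values here, none of the measured steps involves a change of this kind; all three, including a 4.2-fold lower number from compound 1 to compound 2 (0.62 log units; beyond the scatter), swap one group for another. Within the data shown here, with no step to lean on, no shift beyond the scatter is expected, and the step is therefore estimated as a 1.0-fold lower number from compound 3 to compound 4 (0.00 log units; within the scatter). Compound 4 is expected to give about 25000 nM in this assay, within 11000 nM to 55000 nM.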

Compound 4, half-maximal inhibitory concentration: 17900 nM
Estimate against measurement, compound 4: 1.4-fold (0.15 log units) above, and the stated range covers the measured number.
By their numbers in this assay, from the lowest: compounds 2, 4 and 3 (each within the scatter of the next); then compound 1.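

Fixing the stereocentre at the saturated chain carbon as R does not move the number beyond the scatter in this assay, with a 1.4-fold lower number from compound 3 to compound 4 (0.15 log units; within the scatter). The defined form also shows a 1.0-fold higher number from compound 2 to compound 4 (0.01 log units; within the scatter), while a 4.0-fold lower number from compound 1 to compound 4 (0.61 log units; beyond the scatter) remains beyond the scatter. The first of these steps is no comparison of two defined configurations: the fact that one of compounds 3 and 4 is drawn with a defined configuration and the other without, at the place where they differ

From the compounds shown here alone, what the S configuration at this carbon would give in this assay remains open. So does the effect of an amine or a carboxylic acid on the ester chain.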